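Halophenyl swap on the ring nitrogen of the series

A few compounds are considered here, and "the series" means these few. Any claim that something is new, unique, unknown or untested is made for them only; others in the source may bear on it.

Compound 1 `N#CC1=C(N)Oc2c(c3nc4ccccc4nc3c3ccccc23)C12C(=O)N(Cc1cnnn1-c1ccc(F)cc1)c1ccccc12` is tested in a functional assay on MCF7 cells (Homo sapiens) for antiproliferative activity, read by MTT assay, with a stated time of 48 h; on this read-out lower numbers stand for stronger inhibition and higher numbers for weaker inhibition. Compound 1 reaches only the limit of the assay, > 50000 nM, and not a number. Compound 2 `N#CC1=C(N)Oc2c(c3nc4ccccc4nc3c3ccccc23)C12C(=O)N(Cc1cnnn1-c1cccc(Cl)c1)c1ccccc12` gives 43600 nM in this assay. The step of an at least 1.1-fold lower number from compound 1 to compound 2 (0.05 log units; that floor lies within the scatter) rests on a limit on one side, as noted in the limit of > 50000 nM in this assay, at which 1 of the 2 values shown sits, so it sets only a floor for the exchange of 4-fluorophenyl for 3-chlorophenyl on the aromatic nitrogen.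

Compound 3 `N#CC1=C(N)Oc2c(c3nc4ccccc4nc3c3ccccc23)C12C(=O)N(Cc1cnnn1-c1ccccc1Br)c1ccccc12` carries the change (2-bromophenyl in place of 4-fluorophenyl on an aromatic nitrogen). For the measured compounds named here, the single measured step, an at least 1.1-fold lower number from compound 1 to compound 2 (0.05 log units; that floor lies within the scatter), also exchanges the halophenyl on that nitrogen and stays near the limit; no measured step compares a 2-bromophenyl. The expectation for this assay is thus a small move toward a lower number, if any beyond the scatter. A step of an at least 1.1-fold lower number from compound 1 to compound 3 (0.04 log units; that floor lies within the scatter) is expected from this. Compound 3 is estimated at 45000 nM, within 15000 nM to 90000 nM, with a fair chance that only a limit is reported again.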

Compound 3, half-maximal inhibitory concentration: > 50000 nM
Compound 3: a limit, no number (the forecaster's own chance of this, stated with the estimate: 50%); at least 1.1-fold (0.04 log units) between middle value and limit.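

In this assay compound 3 gives > 50000 nM, a limit and not a number. With a 2-bromophenyl on the aromatic nitrogen, the read is an at least 1.1-fold higher number from compound 2 to compound 3 (0.05 log units; that floor lies within the scatter), so a third halophenyl, differing in both halogen and ring position, does not separate from the 3-chlorophenyl of compound 2; the step between the two compounds that stand at the limit cannot be read. The series therefore shows no halophenyl exchange on this nitrogen with a step beyond the scatter, and the read-out offers little room to rank these groups: the limit of > 50000 nM in this assay, at which 2 of the 3 values shown sit.

The compounds shown leave open whether any group on this nitrogen can bring a number clearly clear of that limit, for instance an unsubstituted phenyl, a phenyl carrying an amine or a carboxylic acid, or a longer alkyl chain in place of the aromatic ring. They also leave open whether the halogen or its ring position has any readable influence at all in this assay, since every value shown lies at or close to the limit.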